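Methylselanyl in place of methylsulfanyl on the shared core

The source may report more compounds than this note shows. Statements on the series, on what has been measured and on what is new or still open speak of the compounds shown alone.

Compound 1 `CCCCC[Se]c1nc(NCc2ccc(SC)cc2)c2ccccc2n1` and compound 2 `CSc1ccc(CNc2nc(SC)nc3ccccc23)cc1` are the measured pair of the series. In a functional assay on HTB-54 cells (Homo sapiens) for cytotoxicity, read by MTT assay, with a stated time of 72 h (on this read-out lower numbers stand for stronger inhibition of growth and higher numbers for weaker inhibition of growth), compound 1 gives 40400 nM, and compound 2 gives 7220 nM, the lower of the two numbers; the step of a 5.6-fold lower number from compound 1 to compound 2 (0.75 log units; beyond the scatter) separates them. Compound 3 `CSc1ccc(CNc2nc([Se]C)nc3ccccc23)cc1` differs from compound 2 by a group of 2 heavy atoms (1 carbon, 1 selenium; no ring) in place of a group of 2 heavy atoms (1 carbon, 1 sulfur; no ring), on an aromatic carbon, on an aromatic carbon of a six-membered aromatic ring with 2 nitrogen, between two ring nitrogen atoms. Within the data shown here, the single measured step changes the chain length and the chalcogen together, so no measured step isolates selenium against sulfur. Compound 3 is therefore expected to move by a 1.2-fold higher number from compound 2 to compound 3 (0.10 log units; within the scatter), not beyond the scatter. The estimate for compound 3 in this assay is 9000 nM, between 3000 nM and 27000 nM.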

Compound 3, concentration for 50% growth inhibition: 37900 nM
Beside the measured number, compound 3's estimate is 4.2-fold (0.62 log units) below it, and the stated range ends below it.
By their numbers in this assay, from the lowest: compound 2; then compounds 3 and 1 (each within the scatter of the next).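

At this position, on an aromatic carbon between two ring nitrogen atoms, selenium in place of sulfur with the methyl kept gives a 5.2-fold higher number from compound 2 to compound 3 (0.72 log units; beyond the scatter) in this series, a change that the earlier pair could not isolate. With selenium held, hydrogen in place of butyl on the saturated chain carbon bound to a selenium atom gives a 1.1-fold lower number from compound 1 to compound 3 (0.03 log units; within the scatter) and so stays small at this position. Nothing measured here accounts for the selenium step.

Open, on these data alone, is how an amine or a longer chain on sulfur would read at this position.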